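A Chlorine Enters the Chain of Compound 1

The source may report more compounds than this note shows. Statements on the series, on what has been measured and on what is new or still open speak of the compounds shown alone.

Three esters share one long branched chain and differ only in the group on the oxygen next to a carbonyl group. Compound 1 `CC(/C=C/CC(C)CCCC(C)C)=C\C(=O)OC(C)C` carries an isopropyl group there. In a physicochemical assay for lipophilicity (on this read-out higher numbers stand for higher lipophilicity and lower numbers for lower lipophilicity), compound 1 gives 7.15. Compound 2 `CC#CCOC(=O)/C=C(C)/C=C/CC(C)CCCC(C)C` gives 6.4, and compound 3 `CC(/C=C/CC(C)CCCC(C)C)=C\C(=O)Oc1ccccc1` gives 7.67. Compound 1 thus stands second highest of the three: a number 0.75 log units lower from compound 1 to compound 2 (beyond the scatter), while a number 0.52 log units higher from compound 1 to compound 3 (beyond the scatter). Between the other two, a number 1.27 log units higher from compound 2 to compound 3 (beyond the scatter).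

Compound 4 `CC(/C=C/CC(C)CCCC(C)(C)Cl)=C\C(=O)OC(C)C` keeps the isopropyl ester of compound 1 and instead alters the chain: chloro in place of hydrogen on a saturated chain carbon bound to three saturated chain carbons. Among the compounds with values here, none of the measured steps touches this part of the molecule; all three exchange the group on the oxygen next to a carbonyl group, and their sizes run from modest to large. They therefore offer no direct guide to the new change. With a single chlorine atom entering where a hydrogen leaves, only a modest shift is expected, and the step is estimated as a number 0.35 log units higher from compound 1 to compound 4 (beyond the scatter). Compound 4 is expected to give about 7.5, with a likely range from 7 to 8.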

Compound 4, partition coefficient: 6.85
For compound 4 the middle estimate is 0.65 log units above the measured one; measured number outside the range, below it.
By their numbers in this assay, from the lowest: compound 2; then compounds 4 and 1 (each within the scatter of the next); then compound 3.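

Compounds 1, 2 and 3 differ only in the ester group, and each step among them lies beyond the scatter, so they show nothing about the chain itself. Within the data shown here, compound 4 supplies the first reading at this position: chloro in place of hydrogen on a saturated chain carbon bound to three saturated chain carbons gives, in this assay, a number 0.30 log units lower from compound 1 to compound 4 (within the scatter), so this single exchange, which can also be read as isopropyl to 1-chloro-1-methylethyl, does not separate the two compounds on this read-out. Nothing shown here offers a measured explanation for this result.

Going by these compounds, this is one pair on one ester, so it remains open whether chloro at this carbon would give a similar result alongside the phenyl ester of compound 3 or the but-2-yn-1-yl ester of compound 2. On these data alone, it also remains open whether a different group at the same carbon, such as fluoro, hydroxyl, an amine or a carboxylic acid, would give a step beyond the scatter.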